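The source may hold more compounds than are shown below. What is called first, only, known or untested is meant among the compounds shown, and "the series" means these compounds.

Compound 3, with the structure `C=CC1=C(C(=O)NC(C)(C)C)C(c2ccc(F)cc2)OC1`, is the starting point. In a functional assay on A549 cells (Homo sapiens) for cytotoxicity, read by MTT assay, with a stated time of 24 h (a lower number here means a stronger inhibitor, a higher number a weaker inhibitor), compound 3 gives > 100000 nM, which is a limit of the assay and not a measured number. Its two neighbours in this set stand no differently. Compound 1, with the structure `C=CC1=C(C(=O)NCc2ccccc2F)C(c2ccc(F)cc2)OC1`, gives > 100000 nM in this assay, again a limit. Compound 2, with the structure `C=CC1=C(C(=O)NCC(C)C)C(c2ccc(F)cc2)OC1`, gives > 100000 nM in this assay, also a limit. As a result, the step from compound 1 to compound 2 reads as a step that the two limits leave unreadable from compound 1 to compound 2, the step from compound 1 to compound 3 as a step that the two limits leave unreadable from compound 1 to compound 3, and the step from compound 2 to compound 3 as a step that the two limits leave unreadable from compound 2 to compound 3: all three groups on the amide-type nitrogen leave the read-out unchanged at the limit, as the line the limit of > 100000 nM in this assay, at which 3 of the 3 values shown sit, records.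

Compound 4, with the structure `C=CC1=C(C(=O)NCCCCC)C(c2ccc(F)cc2)OC1`, carries the change (pentyl in place of tert-butyl on an amide-type nitrogen). The three measured steps around compound 3 all bear on this change, and none of them reached a readable size, so no step beyond the scatter is expected from compound 3 to compound 4, an expected step that the limit leaves unreadable from compound 3 to compound 4. Compound 4 is therefore estimated at 150000 nM in this assay, within a range from 50000 nM to 500000 nM, most likely reported again only as a limit.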

Compound 4, half-maximal inhibitory concentration: > 100000 nM
Compound 4 ended at the assay's limit (the forecaster's own chance of this, stated with the estimate: 85%); the middle value lies beyond the limit too.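

Compound 4 gives > 100000 nM in this assay, which is a limit of the assay. Its steps to compound 1, compound 2 and compound 3 cannot be read, because only limits stand on both sides: the limit of > 100000 nM in this assay, at which 4 of the 4 values shown sit.

The compounds shown leave open whether any group on the amide-type nitrogen can give a readable value, and how these four compounds truly compare.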